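Triazene series: acyl change on the shared core

The source may hold more compounds than are shown below. What is called first, only, known or untested is meant among the compounds shown, and "the series" means these compounds.

Measured in a functional assay on HeLa cells (Homo sapiens) for cytotoxicity, read by MTT assay, with a stated time of 72 h (a higher number here means a weaker inhibitor, a lower number a stronger inhibitor), so far:
compound 1, `FC(F)(F)c1cc(/N=N/Nc2ccc(Cl)c(C(F)(F)F)c2)ccc1Cl`, 58400 nM
compound 2, `O=C(c1cccc(C(F)(F)F)c1)N(/N=N/c1ccc([N+](=O)[O-])cc1Br)c1ccc([N+](=O)[O-])cc1Br`, 1120 nM
compound 3, `CC(=O)N(/N=N/c1ccc([N+](=O)[O-])cc1Cl)c1ccc([N+](=O)[O-])cc1Cl`, 630 nM

Compound 3 gives the lowest of the three numbers. The gap to compound 2 is small and falls within the usual scatter, so no order between compound 3 and compound 2 can be read from these figures. Within the data shown here, the gap to compound 1 is large and lies beyond the scatter; compound 1 carries no acyl group on the triazene nitrogen and no nitro groups, so it differs from the others in more than one place and no single step is counted for it.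

Compound 4, `O=C(CCl)N(/N=N/c1ccc([N+](=O)[O-])cc1Cl)c1ccc([N+](=O)[O-])cc1Cl`, has not yet been measured. It differs from compound 3 only by chloro in place of hydrogen on a saturated chain carbon bound to a carbonyl carbon. Among the measured compounds shown here, no step of this kind is counted among the measured compounds, so the expectation rests on compound 3 alone. A small step toward a lower number is expected, not beyond the scatter, given as a 1.4-fold lower number from compound 3 to compound 4 (0.15 log units; within the scatter). For compound 4 in this assay the estimate is 450 nM, with a range from 150 nM to 1500 nM.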

Compound 4, half-maximal inhibitory concentration: 550 nM
Estimate against measurement, compound 4: 1.2-fold (0.09 log units) below; low and high end bracket the measured number.
By their numbers in this assay, from the lowest: compounds 4, 3 and 2 (each within the scatter of the next, the first and the last beyond it); then compound 1.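

In this assay, among these compounds, chloro in place of hydrogen on a saturated chain carbon bound to a carbonyl carbon gives a 1.1-fold lower number from compound 3 to compound 4 (0.06 log units; within the scatter), the first step that changes one place only. At this position, methyl to chloromethyl therefore produces no readable change in the number, and compound 3 and compound 4 cannot be ordered. Nothing measured here offers an explanation for this result.

Still open, on these data alone, is what a larger change at the same chain carbon would do, for example an amine, a hydroxyl or a longer chain in place of the chloro. Compound 1 also still differs from the others in more than one place, so its large gap to them cannot be assigned to any single group.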